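A Methoxy for a Fluoro: Compound 3 Awaits Testing

The source may report more compounds than this note shows. Statements on the series, on what has been measured and on what is new or still open speak of the compounds shown alone.

Two related compounds have been measured in a functional assay on KG-1 cells (Homo sapiens) for cytotoxicity, read by luminescence and CellTiter-Glo, with a stated time of 3 days; a lower number here means a stronger inhibitor, a higher number a weaker inhibitor. Compound 1 `N#Cc1ccc(NC(=O)c2ccc3ccccc3c2O)cc1` gives 2720 nM.

Compound 2 `N#Cc1ccc(NC(=O)c2c(O)cccc2F)cc1` gives > 10000 nM, which is a limit of the assay and not a number. Compound 2 therefore has no exact place on the scale. What this assay has yielded so far comes down to one number and (the limit of > 10000 nM in this assay, at which 1 of the 2 values shown sits).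

Compound 3 `COc1cccc(O)c1C(=O)Nc1ccc(C#N)cc1` has not yet been measured. It differs from compound 2 at one place: methoxy in place of fluoro on an aromatic carbon. In words, methoxy stands in place of fluoro on an aromatic carbon, ortho to a large group and meta to a hydroxy group.

Among the measured compounds shown here, no measured pair in this small set shows such a change, so the expectation is loose. A small step toward a lower number is expected in this assay, and it may not go beyond the scatter. Compound 3 could also stay at the limit. The expected change is an at least 1.2-fold lower number from compound 2 to compound 3 (0.09 log units; that floor lies within the scatter), an estimate set against a limit rather than a number. For compound 3 the estimated value is 8000 nM, with an expected range from 3000 nM to 20000 nM.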

Compound 3, half-maximal inhibitory concentration: > 10000 nM
Compound 3: a limit, no number; the forecaster's own chance of this, stated with the estimate: 50%; at least 1.2-fold (0.09 log units) between middle value and limit.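

Compound 3 gives > 10000 nM, which is a limit of the assay and not a number. Compound 2 also stands at a limit, and no step can be read between compound 2 and compound 3. The compounds shown leave open whether methoxy in place of fluoro on an aromatic carbon changes the value at all.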